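Bromo for Fluoro on the Anilino Ring of Compound 3

The compounds below may be only part of what the source reports. "The series", "measured", "known", "first", "only" and "open" are said of these compounds alone.

Compound 3 `C=CC(=O)Nc1cccc(NC(=O)CSc2nc(Nc3ccccc3F)c3ccccc3n2)c1` gives 6580 nM in a functional assay on NCI-H1975 cells (Homo sapiens) for inhibition, read by MTT assay, with a stated time of 72 h (on this read-out higher numbers stand for weaker inhibition and lower numbers for stronger inhibition), the lowest of the three numbers recorded there. Compound 2 `O=C(CSc1nc(Nc2ccccc2)c2ccccc2n1)Nc1ccc(Br)cc1` gives 10600 nM, a gap within the scatter, while compound 1 `O=C(CSc1nc(Nc2ccccc2)c2ccccc2n1)Nc1ccc(F)cc1` gives 16500 nM, a gap beyond it. Compound 4 `C=CC(=O)Nc1cccc(NC(=O)CSc2nc(Nc3ccccc3Br)c3ccccc3n2)c1` differs from compound 3 by bromo in place of fluoro on an aromatic carbon. Going by the values given here, the only measured step of the same kind, though on the other aromatic ring, is a 1.6-fold lower number from compound 1 to compound 2 (0.19 log units; within the scatter), within the scatter. On that basis the change is expected to move this assay little, if at all, with any shift tending toward a lower number. Compound 4 is therefore estimated at 5000 nM, between 2500 nM and 12000 nM. The expected step is a 1.3-fold lower number from compound 3 to compound 4 (0.12 log units; within the scatter).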

Compound 4, half-maximal inhibitory concentration: 19300 nM
For compound 4 the middle estimate is 3.9-fold (0.59 log units) below the measured one; the whole stated range lies below it.
By their numbers in this assay, from the lowest: compounds 3, 2, 1 and 4 (each within the scatter of the next, the first and the last beyond it).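

In this assay, bromo in place of fluoro on the aromatic carbon ortho to a large group gives a 2.9-fold higher number from compound 3 to compound 4 (0.47 log units; beyond the scatter), so on the core of compound 3 this change weakens inhibition, a shift the earlier step did not show. The change therefore does not read across from one core to the other: the same change on two cores in this assay, a 1.6-fold lower number (0.19 log units; within the scatter) from compound 1 to compound 2 and a 2.9-fold higher number (0.47 log units; beyond the scatter) from compound 3 to compound 4, 4.6-fold (0.66 log units) apart, beyond the scatter of two such steps

The compounds shown leave open how chloro or methyl at this place would read. They also leave open whether plain hydrogen there, on the core of compound 3, would stand nearer compound 3 or compound 4.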